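The source may hold more compounds than are shown below. What is called first, only, known or untested is meant among the compounds shown, and "the series" means these compounds.

Measured so far:
compound 1 `CCN(Cc1cccs1)C(=O)COc1ccc(C(F)(F)F)cc1` — 236 nM
compound 2 `Cc1ccc(OCC(=O)N(Cc2cccs2)c2ncco2)cc1` — 0.3 nM
compound 3 `CCN(Cc1cccs1)C(=O)COc1ccc2c(c1)CCC2` — 0.8 nM

In an assay on HEK293 cells for agonist activity at transient receptor potential cation channel subfamily M member 8 (Homo sapiens), read by fluorescence and calcium flux, with a stated time of 15 min (a lower number here means that less compound is needed, a higher number that more compound is needed for the effect), compound 2 gives 0.3 nM, the lowest of the three numbers. Compound 3 gives 0.8 nM, the nearest value, and the gap between the two lies beyond the usual scatter. Compound 1 gives 236 nM, the furthest value, also beyond the scatter. No two of these three differ in one place only, so none of these gaps can be tied to a single structural change.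

Compound 4 `Cc1ccc(OCC(=O)N(Cc2cccs2)c2cn[nH]c2)cc1` is the next compound to be measured. Compared with compound 2 the change is 1H-pyrazol-4-yl in place of 1,3-oxazol-2-yl on an amide-type nitrogen. Within the data shown here, no measured pair shows the effect of exchanging one five-membered aromatic ring for another on this amide-type nitrogen, so the step has to be judged without a precedent. Given the low value of compound 2 at 0.3 nM, a moderate rise in this assay is expected, though the direction is uncertain and a result within the scatter would not surprise. The estimated step from compound 2 to compound 4 is a 10-fold higher number from compound 2 to compound 4 (1.00 log units; beyond the scatter), and for compound 4 the expected value is 3 nM, in a range from 0.3 nM to 30 nM.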

Compound 4, half-maximal effective concentration: 1.4 nM
Compound 4: the middle estimate sits 2.1-fold (0.33 log units) above what was measured; low and high end bracket the measured number.
By their numbers in this assay, from the lowest: compound 2; then compounds 3 and 4 (each within the scatter of the next); then compound 1.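

Working through this assay, this is the first single-place comparison in the series: on the amide-type nitrogen, 1H-pyrazol-4-yl in place of 1,3-oxazol-2-yl gives a 4.7-fold higher number from compound 2 to compound 4 (0.67 log units; beyond the scatter). The exchange keeps a five-membered aromatic ring with 2 hetero atoms but moves from 0 to 1 hydrogen-bond donor and from 2 to 1 hydrogen-bond acceptors, and compound 4 still gives 1.4 nM. The position therefore accepts both rings with a low number, though the order between them is clear. No measurement available here accounts for the step.

As far as these compounds go, whether the hydrogen-bond donor matters stays open, and a 1-methylpyrazol-4-yl group on this nitrogen would address it. Comparisons of the ethyl group in compounds 1 and 3 with these rings cannot be read, as those compounds also differ elsewhere.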